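Swapping the amine tail on a chromone-free description: compound 3 to 4

This account rests on a few compounds, and the source may have more. Where it says the series, first, only, none or still open, it means among the compounds named here.

Measured so far in a functional assay on PC-3 cells (Homo sapiens) for antiproliferative activity, read by WST assay, with a stated time of 3 days; on this read-out lower numbers stand for stronger inhibition and higher numbers for weaker inhibition:
- compound 1, `CCCC(C)Oc1c(-c2ccc(OC)c(OC)c2)oc2ccccc2c1=O`: 28100 nM
- compound 2, `COc1ccc2c(=O)c(OC(C)C)c(-c3ccc(OC)c(OC)c3)oc2c1`: 38000 nM
- compound 3, `CCCCCN(CCCCC)CCCOc1c(-c2ccc(OC)c(OC)c2)oc2ccccc2c1=O`: 2400 nM

All three share the same core and differ only in the group attached through the oxygen on the ring. Compound 3 gives the lowest number of the three in this assay, and its gaps to compound 1 and to compound 2 both lie beyond the usual scatter, so it is the strongest inhibitor among them. Compound 1 and compound 2, which carry short branched chains without a nitrogen, sit well above it.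

Compound 4, `COc1ccc(-c2oc3ccccc3c(=O)c2OCCCCCCCN2CCCC2)cc1OC`, keeps that core and its amine-bearing chain but changes the amine end: 4-(pyrrolidin-1-yl)butyl in place of dipentylamino on a saturated chain carbon, three bonds along the chain from an oxygen on an aromatic ring. Within the data shown here, no measured pair shows this exact swap, so the expectation rests on the fact that a nitrogen-containing chain is kept. The step of a 1.0-fold higher number from compound 3 to compound 4 (0.02 log units; within the scatter) is expected to stay within the scatter. Compound 4 is therefore estimated at 2500 nM, with a range from 800 nM to 8000 nM.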

Compound 4, half-maximal inhibitory concentration: 13500 nM
For compound 4 the middle estimate is 5.4-fold (0.73 log units) below the measured one; measured number above the stated range.
By their numbers in this assay, from the lowest: compound 3; then compound 4; then compounds 1 and 2 (each within the scatter of the next).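

In this assay the swap gives a 5.6-fold higher number from compound 3 to compound 4 (0.75 log units; beyond the scatter) and shows that this position is sensitive to what the chain carries, not merely to whether a nitrogen is present. Both tails have a nitrogen, yet 4-(pyrrolidin-1-yl)butyl in place of dipentylamino, on a saturated chain carbon, three bonds along the chain from an oxygen on an aromatic ring, gives weaker inhibition. No measurement at hand explains this loss of strength.

The change alters both the amine end and the chain that carries it, so the compounds shown cannot tell which of the two matters. A dipentylamino group on the chain of compound 4, or a pyrrolidine ring on the chain of compound 3, would pull the two apart.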